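Swapping Methoxy for Chloro in Three Measured Growth Inhibitors

The compounds below may be only part of what the source reports. "The series", "measured", "known", "first", "only" and "open" are said of these compounds alone.

Compound 1 `COc1cc(/C=C/C(=O)c2cccc(-n3cc(-c4ccc(Cl)cc4)[nH]c3=O)c2)cc(OC)c1OC` gives 7380 nM in a functional assay on COLO 205 cells (Homo sapiens) for inhibition; a higher number here means a weaker inhibitor of growth, a lower number a stronger inhibitor of growth.
Compound 2 `COc1ccc(-c2cn(-c3cccc(C(=O)/C=C/c4ccc(O)c(OC)c4)c3)c(=O)[nH]2)cc1` gives 6610 nM in this assay.
Compound 3 `COc1ccc(-c2cn(-c3cccc(C(=O)/C=C/c4cc(OC)c(OC)c(OC)c4)c3)c(=O)[nH]2)cc1` gives 1840 nM in this assay.

Compound 3 and compound 2 share a core but differ in one part: 4-hydroxy-3-methoxyphenyl in place of 3,4,5-trimethoxyphenyl on a double-bonded chain carbon bound to a double-bonded chain carbon. That change brought a 3.6-fold lower number from compound 2 to compound 3 (0.56 log units; beyond the scatter), so compound 3 gives the lowest number of the three. Compound 1 and compound 2 give numbers within the scatter of each other, so no order between them can be read.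

Compound 4 `COc1cc(/C=C/C(=O)c2cccc(-n3cc(-c4ccc(Cl)cc4)[nH]c3=O)c2)ccc1O` has not yet been measured. It stands to compound 2 as compound 1 stands to compound 3: chloro in place of methoxy on an aromatic carbon. The change from compound 3 to compound 1 is the same change, (chloro in place of methoxy on an aromatic carbon), and it made a 4.0-fold higher number from compound 3 to compound 1 (0.60 log units; beyond the scatter). The two place descriptions agree word for word, so the same kind of change is being repeated on a different core. The two cores differ as described above in the change from compound 3 to compound 2.

Among the compounds with values here, with only one earlier example of this change, the expected step from compound 2 to compound 4 in this assay is taken to be of similar size and direction, a 3.3-fold higher number from compound 2 to compound 4 (0.52 log units; beyond the scatter), resting on compound 3 to compound 1 giving a 4.0-fold higher number from compound 3 to compound 1 (0.60 log units; beyond the scatter). The expected value for compound 4 is therefore 22000 nM, with a range from 8000 nM to 60000 nM reflecting that the core here is different and the earlier step was seen once.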

Compound 4, concentration for 50% growth inhibition: 3400 nM
Compound 4: the middle estimate sits 6.5-fold (0.81 log units) above what was measured; the whole stated range lies above it.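

Placing chloro where compound 2 carries methoxy, on the aromatic carbon of its 4-methoxyphenyl group, gave a 1.9-fold lower number from compound 2 to compound 4 (0.29 log units; within the scatter), so in this assay this pair cannot be put in any order. Within the data shown here, the step seen on the core of compound 3 therefore did not carry over to the core of compound 2, and the two cores, which differ by 3,4,5-trimethoxyphenyl in place of 4-hydroxy-3-methoxyphenyl, gave clearly different results for one and the same change: the same change on two cores in this assay, a 4.0-fold higher number (0.60 log units; beyond the scatter) from compound 3 to compound 1 and a 1.9-fold lower number (0.29 log units; within the scatter) from compound 2 to compound 4, 7.8-fold (0.89 log units) apart, beyond the scatter of two such steps This shows that, in this series, a step measured on one core is not a safe guide to the step on another, but it does not show why the two results part, and with only two pairs it cannot say which of them is the more typical.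

From the compounds shown here alone, it remains open how the swap from 4-methoxyphenyl to 4-chlorophenyl would read on a core carrying some other group in place of these two, such as a plain phenyl ring or a 4-aminophenyl group. Also open, going by these compounds, is how a fluoro group, an amine or a carboxylic acid would compare with methoxy and chloro at the same place on either core.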